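A few compounds are considered here, and "the series" means these few. Any claim that something is new, unique, unknown or untested is made for them only; others in the source may bear on it.

In a physicochemical assay for metabolic stability, read by HPLC and mass spectrometry, in phosphate buffer, at 37 degrees C, at pH 7.4 (on this read-out higher numbers stand for a longer-lived compound and lower numbers for a shorter-lived compound), compound 1 `CN(C[C@@H]1[C@H](NC(=O)/C(=N\OC(C)(C)C(=O)O)c2csc(N)n2)C(=O)N1S(=O)(=O)O)C(=O)CN` gives 212 h, compound 2 `CC(C)(O/N=C(\C(=O)N[C@@H]1C(=O)N(S(=O)(=O)O)[C@@H]1Cn1ccnn1)c1csc(N)n1)C(=O)O` gives 257 h and compound 3 `CC(C)(O/N=C(\C(=O)N[C@@H]1C(=O)N(S(=O)(=O)O)[C@@H]1Cn1cnnc1)c1csc(N)n1)C(=O)O` gives 113 h. Compound 3 stands apart from compound 2 only, as shown by a 2.3-fold lower number from compound 2 to compound 3 (0.36 log units; beyond the scatter), whereas the data show a 1.9-fold lower number from compound 1 to compound 3 (0.27 log units; within the scatter). The change to compound 4 `CC(C)(O/N=C(\C(=O)N[C@@H]1C(=O)N(S(=O)(=O)O)[C@@H]1CN1C[C@@H](CNC(=N)N)OC1=O)c1csc(N)n1)C(=O)O` is a group of 11 heavy atoms (5 carbon, 4 nitrogen, 2 oxygen; one five-membered non-aromatic ring with 2 hetero atoms) in place of a group of 5 heavy atoms (2 carbon, 3 nitrogen; one five-membered aromatic ring with 3 hetero atoms), on a saturated chain carbon bound to a saturated ring carbon. All three measured steps bear on it, since each exchanges the group at this same place. Besides the two above, the data show a 1.2-fold higher number from compound 1 to compound 2 (0.08 log units; within the scatter). None of these steps is large, so only a small change in this assay is expected, within the scatter and with no firm direction. The expected step is a 1.3-fold higher number from compound 3 to compound 4 (0.12 log units; within the scatter). Compound 4 is estimated at 150 h, with an expected range of 65 h to 340 h.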

Compound 4, half-life: > 37 h
Compound 4: a limit, no number (the forecaster's own chance of this, stated with the estimate: 5%); the middle value is on the limit's open side.
By their numbers in this assay, from the lowest: compounds 3, 1 and 2 (each within the scatter of the next, the first and the last beyond it).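

In this assay compound 4 gives > 37 h as a limit, not a number, so its steps from compound 1, compound 2 and compound 3 cannot be read. The compounds shown leave open where compound 4 stands among these three.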